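A few compounds are considered here, and "the series" means these few. Any claim that something is new, unique, unknown or untested is made for them only; others in the source may bear on it.

Within the data shown here, compound 1, with the structure `Cn1ccc2c(Oc3ccc(NC(=O)c4cc5cccnc5n(-c5ccc(Br)cc5)c4=O)cc3)ncnc21`, is the one member of this set for which a number is reported in a functional assay on MCF7 cells (Homo sapiens) for cytotoxicity, read by MTT assay, with a stated time of 72 h; on this read-out higher numbers stand for weaker inhibition and lower numbers for stronger inhibition: compound 1 gives 79400 nM, a weak effect on this read-out. A second compound of the same core, compound 2 with the structure `Cn1ccc2c(Oc3ccc(NC(=O)c4cc5cccnc5n(-c5ccc(C(F)(F)F)c(Cl)c5)c4=O)cc3)ncnc21`, is reported in this assay as "not active" (no number reported), so no number stands beside it and no comparison can be made between compound 1 and compound 2 beyond saying that compound 1 alone yields a measured value. Compound 1 therefore stands as the only fixed point among the numbers shown.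

Compound 3, with the structure `Cn1ccc2c(Oc3ccc(NC(=O)c4cc5cccnc5n(-c5ccc(Br)cc5)c4=O)cc3F)ncnc21`, is not yet measured in this assay. Among the measured compounds shown here, its single change from compound 1 is fluoro in place of hydrogen on an aromatic carbon, ortho to a large group and meta to a large group on the six-membered aromatic ring of carbon only. For the measured compounds named here, no step between two measured compounds is available to guide the size of this change, so the expected step from compound 1 to compound 3 is estimated as a 1.3-fold lower number from compound 1 to compound 3 (0.12 log units; within the scatter), a movement not beyond the usual scatter in either direction. For compound 3 the estimated value in this assay is 60000 nM, with a range from 20000 nM to 180000 nM.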

Compound 3, half-maximal inhibitory concentration: 59400 nM
Estimate against measurement, compound 3: 1.0-fold (0.00 log units) above; the range from low to high includes it.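

Fluoro in place of hydrogen on an aromatic carbon of the six-membered aromatic ring of carbon only, ortho to a large group and meta to a large group, provides the first readable step in this assay: a 1.3-fold lower number from compound 1 to compound 3 (0.13 log units; within the scatter). Among these compounds, at this place, then, the single added fluoro leaves compound 3 indistinguishable from compound 1 on this read-out, and the series now has a second measured value, whereas compound 2 offered no number for comparison. No measurement shown offers an explanation for this result or links it to any property of the fluoro group.

The compounds shown leave open whether a different group on this same aromatic carbon, such as chloro, methoxy, an amine or a carboxylic acid, would produce a step beyond the scatter, since this single replacement speaks only for fluoro. They also leave open whether fluoro at this place would have the same outcome on the structure of compound 2, which is reported as not active and has no number.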